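Phenyl to 2-fluorophenyl on the shared core

A few compounds are considered here, and "the series" means these few. Any claim that something is new, unique, unknown or untested is made for them only; others in the source may bear on it.

Compound 3 `CC(C)(C)n1ncc(OCc2nnc(-c3ccccc3)s2)c(Cl)c1=O` gives 200 ug/mL in a functional assay on the whole organism for inhibition, with Mythimna separata as the target, with a stated time of 5 days (a lower number here means that less compound is needed, a higher number that more compound is needed for the effect), the highest of the two numbers shown. Compound 1 `CC(C)(C)n1ncc(OCc2nnc(-c3cc(F)c(Cl)cc3Cl)s2)c(Cl)c1=O` gives 67.1 ug/mL in this assay. Compound 2 `Cc1cc(C)cc(-c2nnc(COc3cnn(C(C)(C)C)c(=O)c3Cl)s2)c1` reaches only the assay limit > 300 ug/mL (the limit of > 300 ug/mL in this assay, at which 1 of the 3 values shown sits). Compound 4 `CC(C)(C)n1ncc(OCc2nnc(-c3ccccc3F)s2)c(Cl)c1=O` differs from compound 3 by fluoro in place of hydrogen on an aromatic carbon, phenyl to 2-fluorophenyl, on an aromatic carbon ortho to a large group. Among the compounds with values here, two measured steps bear on it: a 3.0-fold higher number from compound 1 to compound 3 (0.47 log units; beyond the scatter), where loss of the halogenated ring raised the number, and an at least 1.5-fold lower number from compound 2 to compound 3 (0.17 log units; that floor lies within the scatter), which stays within the scatter. Given a 3.0-fold higher number from compound 1 to compound 3 (0.47 log units; beyond the scatter), a modest lowering is expected for compound 4, a 1.5-fold lower number from compound 3 to compound 4 (0.19 log units; within the scatter), though a change within the scatter remains possible. Compound 4 is estimated at 130 ug/mL, within 55 ug/mL to 300 ug/mL.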

Compound 4, half-maximal effective concentration: 121 ug/mL
Compound 4: the middle estimate sits 1.1-fold (0.03 log units) above what was measured; measured number inside the range.
By their numbers in this assay, from the lowest: compounds 1, 4 and 3 (each within the scatter of the next, the first and the last beyond it). At a limit, above all of these: compound 2.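

In this assay, 2-fluorophenyl in place of phenyl gives only a step within the scatter (a 1.7-fold lower number from compound 3 to compound 4 (0.22 log units; within the scatter)), and the step to the 2,4-dichloro-5-fluorophenyl ring also stays within it (a 1.8-fold higher number from compound 1 to compound 4 (0.26 log units; within the scatter)). Fluoro alone on this aromatic carbon, ortho to a large group, therefore separates compound 4 from neither compound 1 nor compound 3, although those two lie beyond the scatter of each other. Compound 2 stands at a limit, and the step from it lies beyond the scatter (an at least 2.4-fold lower number from compound 2 to compound 4 (0.39 log units; beyond the scatter)). Still open, as far as these compounds go, is whether chloro, methoxy or an amine on this carbon would move the number beyond the scatter.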